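Replacing 4-bromophenyl with 2,4-dichlorophenyl in compound 3

This account rests on a few compounds, and the source may have more. Where it says the series, first, only, none or still open, it means among the compounds named here.

Measured in a functional assay on MCF7 cells (Homo sapiens); a lower number here means a stronger inhibitor of growth, a higher number a weaker inhibitor of growth:
Compound 1 `N#Cc1ccc(/C=C/S(=O)(=O)Cc2ccc(Nc3ncnc4ccccc34)cc2)cc1`: > 100000 nM (a limit of the assay, not a number)
Compound 2 `O=S(=O)(/C=C/c1ccc(Br)cc1)Cc1ccc(Nc2ncnc3ccccc23)cc1`: 91000 nM

Within the data shown here, compound 2 gives 91000 nM in this assay, the only true number in this small set. The other value, that of compound 1, is a limit of the assay. Compound 3 `O=S(=O)(/C=C/c1ccc(Cl)cc1Cl)Cc1ccc(Nc2ncnc3ccccc23)cc1` has not yet been measured. It keeps the core of compound 2 and carries 2,4-dichlorophenyl in place of 4-bromophenyl on a double-bonded chain carbon bound to a double-bonded chain carbon.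

Among the measured compounds shown here, only one measured step bears on this change: an at least 1.0-fold lower number from compound 1 to compound 2 (0.04 log units; that floor lies within the scatter). It came with bromo in place of cyano on an aromatic carbon, and its starting point is a limit (the limit of > 100000 nM in this assay, at which 1 of the 2 values shown sits). For the measured compounds named here, its floor lies within the scatter, so it gives no firm size, and no measured step covers the new 2,4-dichlorophenyl group. No shift beyond the scatter is therefore expected in this assay, with at most a slight lean towards a lower number. The expected step is a 1.3-fold lower number from compound 2 to compound 3 (0.11 log units; within the scatter). For compound 3 the estimated value is 70000 nM, with an expected range of 20000 nM to 100000 nM.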

Compound 3, concentration for 50% growth inhibition: 4000 nM
Compound 3: the middle estimate sits 18-fold (1.24 log units) above what was measured; measured number outside the range, below it.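

In this assay, the group on the double-bonded chain carbon proves able to move the number well beyond the scatter: 2,4-dichlorophenyl in place of 4-bromophenyl gives a 23-fold lower number from compound 2 to compound 3 (1.36 log units; beyond the scatter). Against the 4-cyanophenyl group, the same 2,4-dichlorophenyl group gives an at least 25-fold lower number from compound 1 to compound 3 (1.39 log units; beyond the scatter), whereas the only earlier step, an at least 1.0-fold lower number from compound 1 to compound 2 (0.04 log units; that floor lies within the scatter), gave no firm size. The later step is also a floor rather than a full size, as the value of compound 1, > 100000 nM, is a limit of the assay: the limit of > 100000 nM in this assay, at which 1 of the 3 values shown sits.

The change from 4-bromophenyl to 2,4-dichlorophenyl swaps bromine for chlorine and also adds a second halogen, and the compounds shown cannot separate these two parts, so it remains open whether a phenyl ring with a single chlorine would give a similar step. From the compounds shown here alone, it also remains open whether the gain depends on chlorine itself or would extend to a phenyl ring carrying two fluorines, two methyl groups or a methoxy group.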